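A Halogen Swap on the Pendant Phenyl Ring

The source may hold more compounds than are shown below. What is called first, only, known or untested is meant among the compounds shown, and "the series" means these compounds.

Compound 2 `COc1cc(-n2cnc3ccc(-c4ccc(F)cc4)cc32)cc(OC)c1OC` carries a 4-fluorophenyl group on the shared core. In a functional assay on SGC-7901 cells (Homo sapiens) for antiproliferative activity, read by MTT assay, with a stated time of 72 h (a lower number here means a stronger inhibitor, a higher number a weaker inhibitor), compound 2 gives 3500 nM, the highest of the two numbers at hand. Its nearest neighbour, compound 1 `COc1cc(-n2cnc3ccc(-c4cccc(N)c4)cc32)cc(OC)c1OC`, gives 21 nM in this assay. For the measured compounds named here, the single measured step, a 170-fold higher number from compound 1 to compound 2 (2.22 log units; beyond the scatter), shows that what sits on the pendant phenyl ring governs the read-out strongly.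

Compound 3 `COc1cc(-n2cnc3ccc(-c4cccc(Cl)c4)cc32)cc(OC)c1OC` has not yet been measured. It differs from compound 2 by 3-chlorophenyl in place of 4-fluorophenyl on an aromatic carbon. Going by the values given here, the one measured step bears on this only in part: it exchanged 3-aminophenyl for 4-fluorophenyl, so both the group and its name changed at once, and no measured pair separates the two parts of that change. Compound 3 keeps a halogen, unlike compound 1, so a step as large as the measured one is not expected, yet its direction is uncertain.

Compound 3 is therefore expected to give about 1000 nM, within a range of 150 nM to 7000 nM. This corresponds to an expected step of a 3.5-fold lower number from compound 2 to compound 3 (0.54 log units; beyond the scatter), a modest move toward a lower number whose range still includes no change beyond the scatter.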

Compound 3, half-maximal inhibitory concentration: 1490 nM
Compound 3: the middle estimate sits 1.5-fold (0.17 log units) below what was measured, and the stated range covers the measured number.
By their numbers in this assay, from the lowest: compound 1; then compound 3; then compound 2.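

In this assay the exchange of 4-fluorophenyl for 3-chlorophenyl gives a 2.3-fold lower number from compound 2 to compound 3 (0.37 log units; beyond the scatter) and so shows that the number still moves beyond the scatter when one halogen-bearing phenyl group replaces another, although this step changes both the halogen and where it sits on the phenyl ring. Chloro in place of amino, with the group kept at the same place on the phenyl ring, gives a 71-fold higher number from compound 1 to compound 3 (1.85 log units; beyond the scatter) and is a far larger step than the one between the two halogen-bearing compounds, so in this series the amino group of compound 1 stands apart from both halogens. Nothing at hand gives a measured reason for either step.

The compounds shown leave open how much of the modest step belongs to the halogen and how much to its place, a question that 3-fluorophenyl or 4-chlorophenyl on the shared core would address. They also leave open whether the low number of compound 1 is particular to the amino group or would be shared by a 3-hydroxyphenyl or 3-(methylamino)phenyl group.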